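The compounds below may be only part of what the source reports. "The series", "measured", "known", "first", "only" and "open" are said of these compounds alone.

Compound 1 `CC(C)(C)c1nnc2c(C#N)c(N3CCC(c4ccccc4)CC3)ccn12` gives 1230 nM in a functional assay on CHO cells for positive allosteric modulation of metabotropic glutamate receptor 2 (Homo sapiens), read by GTPgammaS binding, with a stated time of 30 min; on this read-out lower numbers stand for an effect already at smaller amounts and higher numbers for an effect only at larger amounts of compound.
Compound 2 `Fc1ccc(C2CCN(c3ccn4c(CC5CC5)nnc4c3C(F)(F)F)CC2)c(F)c1` gives 10 nM in this assay.

Within the data shown here, compound 2 holds the lower of the two numbers measured so far; compound 1 lies far beyond the scatter from it, and no single-change step between measured compounds links the pair. Compound 3 `FC(F)(F)c1c(N2CCC(c3cccnc3)CC2)ccn2c(CC3CC3)nnc12` differs from compound 2 by pyridin-3-yl in place of 2,4-difluorophenyl on a saturated ring carbon. Among the measured compounds shown here, no measured step shows what this exchange does in this assay. The expected 4.0-fold higher number from compound 2 to compound 3 (0.60 log units; beyond the scatter) is a moderate loss, somewhat beyond the scatter. Compound 3 is estimated at 40 nM, with a range of 10 nM to 160 nM.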

Compound 3, half-maximal effective concentration: 519 nM
Estimate against measurement, compound 3: 13-fold (1.11 log units) below; measured number above the stated range.
By their numbers in this assay, from the lowest: compound 2; then compound 3; then compound 1.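

This carbon of the saturated ring now has its first measured step: pyridin-3-yl in place of 2,4-difluorophenyl gives a 52-fold higher number from compound 2 to compound 3 (1.72 log units; beyond the scatter) in this assay. The exchange is therefore far from neutral, and the aromatic ring at this place weighs heavily on the read-out. Nothing available bears on the reason for this step.

This single change cannot separate the departure of the fluorines from the entry of the ring nitrogen. On these data alone, whether 4-fluorophenyl or pyridin-4-yl on the same carbon, with the rest of compound 2 kept, would stay nearer compound 2 or compound 3 remains open.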